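Swapping Chloro for Nitro on the Pendant Aryl Ring

The source may report more compounds than this note shows. Statements on the series, on what has been measured and on what is new or still open speak of the compounds shown alone.

Of the compounds shown here, three built on a shared core have been tested in an ADME assay on TZM cells (Homo sapiens) for cytotoxicity, read by CellTiter-Glo, with a stated time of 48 h; on this read-out higher numbers stand for lower toxicity in this test and lower numbers for higher toxicity in this test. Compound 1 `COc1ccc(C2=Cc3ccc(F)cc3C(CC(C)=O)N2c2ccc(O)cc2)cc1` gives 60500 nM. Compound 2 `COc1ccc(C2=Cc3ccc([N+](=O)[O-])cc3C(CC(C)=O)N2c2ccc(C)cc2)cc1` gives 10600 nM. Compound 3 `COc1ccc(C2=Cc3ccc(F)cc3C(CC(=O)CO)N2c2ccc(Cl)cc2)cc1` gives 8500 nM, the lowest of the three numbers; its value and that of compound 2 lie within the usual scatter, so no order between them can be read, while the number for compound 1 sits higher by a gap that goes beyond the scatter.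

Compound 4 `COc1ccc(C2=Cc3ccc(F)cc3C(CC(=O)CO)N2c2ccc([N+](=O)[O-])cc2)cc1` has not yet been measured. It differs from compound 3 in one place: nitro in place of chloro on an aromatic carbon. Going by the values given here, no pair among the measured compounds isolates this exact change. Compound 2 carries a nitro group on a different ring and gives 10600 nM, close to the number for compound 3. On that basis the step is expected to be small, a 1.1-fold higher number from compound 3 to compound 4 (0.02 log units; within the scatter), and not beyond the scatter in either direction. Compound 4 is therefore estimated at 9000 nM, with a range from 3000 nM to 30000 nM.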

Compound 4, half-maximal cytotoxic concentration: 46400 nM
Compound 4: the middle estimate sits 5.2-fold (0.71 log units) below what was measured; the measured number lies above the stated range.
By their numbers in this assay, from the lowest: compounds 3 and 2 (each within the scatter of the next); then compounds 4 and 1 (each within the scatter of the next).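

In this assay, going from 4-chlorophenyl to 4-nitrophenyl gives a 5.5-fold higher number from compound 3 to compound 4 (0.74 log units; beyond the scatter), so the group on this aromatic carbon, para to a large group, can shift the read-out beyond the usual scatter. The earlier compounds shown here could not show this: no two of them differ in one place alone, and the nitro group of compound 2 sits on a different ring. Here a higher number means lower toxicity in this test, so on this core, nitro in place of chloro goes with lower toxicity.

Whether an amine or a carboxylic acid at this position would give a number nearer compound 3 or compound 4 remains open, and no measurement shown explains why the number rises with this change.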